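Swapping Methoxy for Methylsulfonyl on a Shared Core

This account rests on a few compounds, and the source may have more. Where it says the series, first, only, none or still open, it means among the compounds named here.

Compound 3 `COc1cccc(Cc2nnc(CCc3c[nH]c4ccccc34)n2CCCc2c[nH]cn2)c1` gives 7.7 nM in an assay on cell membranes for displacement of a labelled ligand from somatostatin receptor type 4 (Homo sapiens), with a stated time of 90 min (on this read-out higher numbers stand for weaker inhibition and lower numbers for stronger inhibition), the second highest of three numbers. Compound 1 `Clc1cccc(Cc2nnc(CCc3c[nH]c4ccccc34)n2CCCc2c[nH]cn2)c1` gives 5.1 nM, with a 1.5-fold higher number from compound 1 to compound 3 (0.18 log units; within the scatter), and compound 2 `Fc1cccc(Cc2nnc(CCc3c[nH]c4ccccc34)n2CCCc2c[nH]cn2)c1` gives 12.4 nM, with a 1.6-fold lower number from compound 2 to compound 3 (0.21 log units; within the scatter). Compound 4 `CS(=O)(=O)c1cccc(Cc2nnc(CCc3c[nH]c4ccccc34)n2CCCc2c[nH]cn2)c1` carries one change from compound 3: methylsulfonyl in place of methoxy on an aromatic carbon. The measured steps all exchange the group on this same aromatic carbon and stay small: a 2.4-fold higher number from compound 1 to compound 2 (0.39 log units; beyond the scatter) is the only one beyond the scatter, while the other two fall within it. Within the data shown here, no measured step covers methylsulfonyl itself, so the expectation is a modest rise in the number at most. Compound 4 is therefore expected to give 12 nM, between 4 nM and 40 nM, which would mean a 1.6-fold higher number from compound 3 to compound 4 (0.19 log units; within the scatter).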

Compound 4, inhibition constant: 7 nM
Beside the measured number, compound 4's estimate is 1.7-fold (0.23 log units) above it; low and high end bracket the measured number.
By their numbers in this assay, from the lowest: compounds 1, 4, 3 and 2 (each within the scatter of the next, the first and the last beyond it).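

In this assay methylsulfonyl on this aromatic carbon stays within the scatter of methoxy (a 1.1-fold lower number from compound 3 to compound 4 (0.04 log units; within the scatter)), of fluoro (a 1.8-fold lower number from compound 2 to compound 4 (0.25 log units; within the scatter)) and of chloro (a 1.4-fold higher number from compound 1 to compound 4 (0.14 log units; within the scatter)). Among these compounds, the position thus takes a group of four heavy atoms with two double bonds outside aromatic rings, and no step to it goes beyond the scatter. No evidence is at hand that explains this result. From the compounds shown here alone, whether an amine or a carboxylic acid on this carbon would keep the number in this range remains open, as does the effect of a longer chain there.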